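The source may hold more compounds than are shown below. What is called first, only, known or untested is meant among the compounds shown, and "the series" means these compounds.

Measured in an ADME assay on MT2 cells (Homo sapiens) for cytotoxicity, read by XTT assay, with a stated time of 4 days; on this read-out higher numbers stand for lower toxicity in this test and lower numbers for higher toxicity in this test:

Compound 1 `Cc1nc2c(c(-c3cc(F)c4c(c3C)CCCO4)c1[C@H](OC(C)(C)C)C(=O)O)CN(CCCc1cccc(F)c1)CC2` gives > 40000 nM, which is a limit of the assay and not a number.
Compound 2 `Cc1ccc(-c2c3c(nc(C)c2[C@H](OC(C)(C)C)C(=O)O)CCN(CCCc2ccccc2)C3)cc1` gives > 40000 nM, likewise a limit and not a number.

Within the data shown here, compound 1 therefore stands at the top of what this assay reports, with no number of its own; the one further value shown, that of compound 2, is also a limit, so both values shown sit at the same limit (the limit of > 40000 nM in this assay, at which 2 of the 2 values shown sit). Among the measured compounds shown here, no step between two measured compounds is available, and nothing yet shows how any single structural change moves this read-out.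

Compound 3 `Cc1ccc(CCCN2CCc3nc(C)c([C@H](OC(C)(C)C)C(=O)O)c(-c4cc(F)c5c(c4C)CCCO5)c3C2)cc1F` differs from compound 1 in one place: methyl in place of hydrogen on an aromatic carbon. With both measured values sitting at the limit, no move in this assay beyond the usual scatter is expected from this change, in either direction. The step from compound 1 to compound 3 is expected to be a step that the limit leaves unreadable from compound 1 to compound 3. Compound 3 is expected to come back once more as a limit rather than a number, and its estimate is 45000 nM, with a range from 20000 nM to 100000 nM.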

Compound 3, half-maximal cytotoxic concentration: > 40000 nM
Compound 3 ended at the assay's limit; the forecaster's own chance of this, stated with the estimate: 85%; the middle value lies beyond the limit too.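

In this assay, among these compounds, compound 3 gives > 40000 nM as a limit and not a number, so no step from compound 1 to compound 3 can be read. All values shown sit at the same limit: the limit of > 40000 nM in this assay, at which 3 of the 3 values shown sit.

Open: whether methyl in place of hydrogen on the aromatic carbon moves this read-out at all, and at what concentration any of these compounds becomes cytotoxic.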